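Working notes on cytotoxicity across a small series

The source may report more compounds than this note shows. Statements on the series, on what has been measured and on what is new or still open speak of the compounds shown alone.

Measured so far:
compound 1, `O=[N+]([O-])c1cn2c(n1)OCC(COCc1ccc(OCc3ccccc3)cc1)C2`, 113000 nM
compound 2, `O=[N+]([O-])c1cn2c(n1)OCC(COc1ccc(-c3ccc(C(F)(F)F)cc3)cn1)C2`, > 128000 nM
compound 3, `O=[N+]([O-])c1cn2c(n1)OCC(COCc1ccc(-c3ccc(OC(F)(F)F)cc3)cc1)C2`, > 128000 nM

The read-out here is an ADME assay on Vero cells (Chlorocebus sabaeus) for cytotoxicity, with a stated time of 72 h; on this read-out lower numbers stand for stronger inhibition and higher numbers for weaker inhibition. Compound 1 gives 113000 nM. For compound 2 the value is a limit of the assay and not a number: > 128000 nM. For compound 3 the value is likewise a limit and not a number: > 128000 nM. Compound 3 thus stands at the upper edge of what was measured, together with one other value; (the limit of > 128000 nM in this assay, at which 2 of the 3 values shown sit). Among the measured compounds shown here, no pair among the three differs in one place, so no measured step is available to calibrate the next change.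

The unmeasured compound 4 is `O=[N+]([O-])c1cn2c(n1)OCC(COCc1ccc(-c3ccc(F)cc3)cc1)C2`. Relative to compound 3 the change is fluoro in place of trifluoromethoxy on an aromatic carbon. With compound 3 itself sitting at a limit, no step beyond the scatter is expected in this assay in either direction. Compound 4 is therefore estimated at 128000 nM, within 60000 nM to 300000 nM. The expected step is a number no higher from compound 3 to compound 4 (the limit leaves the size open).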

Compound 4, half-maximal inhibitory concentration: 24000 nM
The estimate for compound 4 lay 5.3-fold (0.73 log units) above the measured number; measured number below the stated range.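

In this assay, among the compounds shown here, this is the first change at this place that can be read: with fluoro in place of trifluoromethoxy, on an aromatic carbon para to a large group, the result is an at least 5.3-fold lower number from compound 3 to compound 4 (0.72 log units; beyond the scatter). The series therefore responds to this one substituent, and 4-fluorophenyl in place of benzyloxy likewise gives a 4.7-fold lower number from compound 1 to compound 4 (0.67 log units; beyond the scatter). Compound 3 carries a limit and not a number, so the full size of its step stays open: the limit of > 128000 nM in this assay, at which 2 of the 4 values shown sit.

As far as these compounds go, it remains open whether the lower number follows fluoro itself or simply the loss of trifluoromethoxy; a chloro, a methoxy or an amine at the same place would separate the two. Also open, from the compounds shown here alone, is whether fluoro in place of trifluoromethyl would have a similar outcome in compound 2, which also carries a limit.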